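One group exchanged on a carbonyl carbon

The compounds below may be only part of what the source reports. "The series", "measured", "known", "first", "only" and "open" are said of these compounds alone.

In a functional assay on MDA-MB-231 cells (Homo sapiens) for antiproliferative activity, read by sulforhodamine B assay, with a stated time of 48 h (on this read-out lower numbers stand for stronger inhibition and higher numbers for weaker inhibition), compound 1 `COc1ccc(C(=O)/C=C\Nc2ccc(-c3nc4cc(OC)c(OC)c(OC)c4s3)cc2C)cc1[N+](=O)[O-]` gives 12400 nM and compound 2 `COc1ccc(C(=O)/C=C\Nc2ccc(-c3nc4cc(OC)c(OC)c(OC)c4s3)cc2)cc1[N+](=O)[O-]` gives 17100 nM so these two compounds stand within the scatter of each other, and neither can be ranked above the other. For the measured compounds named here, the only measured step is a 1.4-fold higher number from compound 1 to compound 2 (0.14 log units; within the scatter) and it concerns hydrogen in place of methyl on an aromatic carbon, elsewhere in the molecule.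

Compound 3 `COc1cc(C(=O)/C=C\Nc2ccc(-c3nc4cc(OC)c(OC)c(OC)c4s3)cc2)cc(OC)c1OC` shares the core of compound 2 and differs by 3,4,5-trimethoxyphenyl in place of 4-methoxy-3-nitrophenyl on a carbonyl carbon at the carbonyl carbon. Going by the values given here, no measured compound tests an exchange at this place, so the small step above offers only weak guidance and gives no direction. A change beyond the scatter in this assay is therefore not expected, although the uncertainty remains wide. The estimated step is a 1.4-fold lower number from compound 2 to compound 3 (0.15 log units; within the scatter) and it rests on no direct evidence. Compound 3 is expected at 12000 nM with an estimated range from 3000 nM to 40000 nM on this read-out.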

Compound 3, half-maximal inhibitory concentration: 16500 nM
Estimate against measurement, compound 3: 1.4-fold (0.14 log units) below, and the stated range covers the measured number.
By their numbers in this assay, from the lowest: compounds 1, 3 and 2 (each within the scatter of the next).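

For the compounds shown here, at the carbonyl carbon, 3,4,5-trimethoxyphenyl in place of 4-methoxy-3-nitrophenyl gives a 1.0-fold lower number from compound 2 to compound 3 (0.02 log units; within the scatter) in this assay, the first measured exchange at this place, and it lies within the scatter. The group that leaves carries a nitrogen and a double bond outside aromatic rings, the group that enters carries neither, and the count of hydrogen-bond acceptors stays the same, yet compound 2 and compound 3 cannot be ranked. Nothing measured here bears on why these two groups read alike.

As far as these compounds go, both groups tested on the carbonyl carbon are substituted phenyl groups, so it stays open whether an amine, a carboxylic acid or a longer alkyl chain at this place would move the number beyond the scatter. From the compounds shown here alone, whether the exchange reads the same alongside the methyl of compound 1 also stays open.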